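Dropping one hydroxyethyl arm from an inactive urea

A few compounds are considered here, and "the series" means these few. Any claim that something is new, unique, unknown or untested is made for them only; others in the source may bear on it.

Compound 1, `COc1ccc(C(=NNC(=O)NNC(=O)NCCCC(C)Nc2cc(OC)cc3cccnc23)c2ccc(OC)cc2)cc1`: 8000 nM
Compound 2, `COc1cc(NC(C)CCCNC(=O)NNC(=O)N(CCO)CCO)c2ncccc2c1`: > 250000 nM, a limit of the assay and not a number

Both were tested in a functional assay on CCRF-CEM cells (Homo sapiens) for inhibition, read by MTT assay, with a stated time of 4 days; on this read-out higher numbers stand for weaker inhibition and lower numbers for stronger inhibition. Compound 1 is the only one of the two with a measured number. Compound 2 stands at the edge of what the test can see: the limit of > 250000 nM in this assay, at which 1 of the 2 values shown sits. The two compounds differ in many places at once, so no single structural step can be read from the gap between them.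

Compound 3, `COc1cc(NC(C)CCCNC(=O)NNC(=O)NCCO)c2ncccc2c1`, is the untested neighbour of compound 2. It differs in one place: hydrogen in place of 2-hydroxyethyl on an amide-type nitrogen. Among the measured compounds shown here, no measured pair with this change exists here, so the expectation rests on compound 2 alone. The step of a number no higher from compound 2 to compound 3 (the limit leaves the size open) is expected to be none beyond the scatter, most likely leaving compound 3 at the limit as well. Compound 3 is estimated at 250000 nM, within a range from 50000 nM to 1000000 nM.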

Compound 3, half-maximal inhibitory concentration: > 250000 nM
Compound 3: only a limit was reported; the forecaster's own chance of this, stated with the estimate: 70%; the middle value lies on the limit itself.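

In this assay compound 3 gives > 250000 nM, a limit of the assay and not a number. Compound 2 also stands at a limit, so no step can be read between compound 2 and compound 3. On these data alone, whether hydrogen in place of 2-hydroxyethyl on an amide-type nitrogen changes inhibition at all stays open.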